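Replacing phenoxy with naphthalen-1-yl on the quinoline-type core

This account rests on a few compounds, and the source may have more. Where it says the series, first, only, none or still open, it means among the compounds named here.

Three analogues sharing one core have been measured in an ADME assay on HepG2 cells (Homo sapiens) for cytotoxicity, read by luminescence, CellTiter-Glo and ATP content, with a stated time of 72 h; on this read-out higher numbers stand for an effect only at larger amounts of compound and lower numbers for an effect already at smaller amounts. Compound 1 `COc1cccc(CNCCCNc2ccnc3cc(Oc4ccccc4)ccc23)c1O` gives 6800 nM in this assay. Compound 2 `CC(C)(C)c1ccc(Oc2ccc3c(NCCCNCc4ccco4)ccnc3c2)cc1` gives 3100 nM. Compound 3 `c1ccc(Oc2ccc3c(NCCCNCc4ccco4)ccnc3c2)cc1` gives 15200 nM, the highest of the three numbers; the steps to it were a 2.2-fold higher number from compound 1 to compound 3 (0.35 log units; beyond the scatter) and a 4.9-fold higher number from compound 2 to compound 3 (0.69 log units; beyond the scatter).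

Compound 4 `c1coc(CNCCCNc2ccnc3cc(-c4cccc5ccccc45)ccc23)c1` is not yet measured. It differs from compound 3 at the aryl group on the core: naphthalen-1-yl in place of phenoxy on an aromatic carbon

Among the measured compounds shown here, no measured step exchanges the phenoxy itself. For the measured compounds named here, the closest precedent is the step on that same ring, where removal of tert-butyl gave the step of a 4.9-fold higher number from compound 2 to compound 3 (0.69 log units; beyond the scatter); the other step, a 2.2-fold higher number from compound 1 to compound 3 (0.35 log units; beyond the scatter), concerns the far end of the chain and bears less on this change. Given that compound 2 sits at 3100 nM, a change at this position is expected to move the number down rather than up, by a modest amount. The step from compound 3 to compound 4 is therefore estimated as a 2.5-fold lower number from compound 3 to compound 4 (0.40 log units; beyond the scatter). Compound 4 is expected to give about 6000 nM in this assay, within a range of 2500 nM to 15000 nM.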

Compound 4, half-maximal effective concentration: 5600 nM
Beside the measured number, compound 4's estimate is 1.1-fold (0.03 log units) above it; low and high end bracket the measured number.
By their numbers in this assay, from the lowest: compounds 2, 4 and 1 (each within the scatter of the next, the first and the last beyond it); then compound 3.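

Swapping the whole phenoxy group, rather than only a substituent on its ring, also changes the number: in this assay, the change to naphthalen-1-yl gives a 2.7-fold lower number from compound 3 to compound 4 (0.43 log units; beyond the scatter). The position therefore accepts an aryl group with no ether oxygen and two six-membered aromatic rings, and the read-out still responds, with compound 4 and compound 2 lying within the scatter of each other even though they carry different groups at this position. No measurement at hand explains the shift.

The compounds shown cannot separate the loss of the ether oxygen from the gain of a second aromatic ring; phenyl or naphthalen-2-yl at the same carbon would help to tell these apart. Also open, going by these compounds, is whether a carboxylic acid or an amine on the naphthalene ring would move the number in either direction.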